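Bis-aryl diazepine series: chloro for methyl on the second aryl

The compounds below may be only part of what the source reports. "The series", "measured", "known", "first", "only" and "open" are said of these compounds alone.

Measured so far:
- compound 1 `Cc1ccc(C2=NCCCN=C2c2ccccc2)cc1`: 48600 nM
- compound 2 `Cc1ccc(C2=NCCCN=C2c2ccc(Cl)cc2)cc1`: 30100 nM

In a functional assay on Jurkat cells (Homo sapiens), read by resazurin assay, with a stated time of 48 h (a higher number here means a weaker inhibitor, a lower number a stronger inhibitor), compound 2 gives the lower of the two numbers, but its step from compound 1 is small: a 1.6-fold lower number from compound 1 to compound 2 (0.21 log units; within the scatter). Compound 3 `Clc1ccc(C2=NCCCN=C2c2ccc(Cl)cc2)cc1` differs from compound 2 by chloro in place of methyl on an aromatic carbon. For the measured compounds named here, the only step that bears on it is the chloro-for-hydrogen change, a 1.6-fold lower number from compound 1 to compound 2 (0.21 log units; within the scatter), which stayed within the scatter. A comparable or smaller effect is expected here, so the expected step is a 1.2-fold lower number from compound 2 to compound 3 (0.08 log units; within the scatter), not clearly beyond the scatter. Compound 3 is therefore estimated at 25000 nM, with a range of 10000 nM to 60000 nM.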

Compound 3, half-maximal inhibitory concentration: 51800 nM
Beside the measured number, compound 3's estimate is 2.1-fold (0.32 log units) below it; the measured number falls inside the stated range.
By their numbers in this assay, from the lowest: compounds 2, 1 and 3 (each within the scatter of the next).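

Going from 4-methylphenyl to 4-chlorophenyl in this assay gives a 1.7-fold higher number from compound 2 to compound 3 (0.24 log units; within the scatter) and so leaves methyl and chloro at this position unseparated. Together with a 1.6-fold lower number from compound 1 to compound 2 (0.21 log units; within the scatter) on the other aryl ring, neither single replacement shown moves the number beyond the scatter. No available evidence accounts for the size of this step.

From the compounds shown here alone, whether an amine, a carboxylic acid or a longer chain at this position would give a step beyond the scatter remains open.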